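Moving the methoxymethyl group along the chain in compound 4

A few compounds are considered here, and "the series" means these few. Any claim that something is new, unique, unknown or untested is made for them only; others in the source may bear on it.

Measured compounds:
- compound 1, `COC[C@@H](C(C)C)C(c1ccc(O)c(OC)c1)c1ccc(O)c(OC)c1`: 54000 nM
- compound 2, `COc1cc(C(c2ccc(O)c(OC)c2)[C@H](C)[C@H](C)CF)ccc1O`: 56000 nM
- compound 3, `COC[C@H](C(C)C)C(c1ccc(O)c(OC)c1)c1ccc(O)c(OC)c1`: 72000 nM

These three share a core carrying two aromatic rings on one saturated chain carbon, and differ only in the branched group on that carbon. In a functional assay on HL-60 cells (Homo sapiens) for cytotoxicity, read by WST assay, with a stated time of 48 h (on this read-out lower numbers stand for stronger inhibition and higher numbers for weaker inhibition), compound 3 gives 72000 nM. Compound 3 sits at the upper end of the three numbers, yet its distances to its neighbours, a 1.3-fold higher number from compound 2 to compound 3 (0.11 log units; within the scatter) and a 1.3-fold higher number from compound 1 to compound 3 (0.12 log units; within the scatter), both lie within the scatter. The last of these rests on (the fact that compounds 1 and 3 differ only in the configuration as drawn). Swapping the whole branched group, as in a 1.0-fold higher number from compound 1 to compound 2 (0.02 log units; within the scatter), also stayed within the scatter.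

Compound 4 is `COC[C@@H](C)[C@H](C)C(c1ccc(O)c(OC)c1)c1ccc(O)c(OC)c1`. Its change from compound 3 is 2-(methoxymethyl)-1-methylpropyl in place of 1-(methoxymethyl)-2-methylpropyl on a saturated chain carbon bound to two aromatic carbons. Every measured change of this branched group left the number where it was, so no step beyond the scatter is expected for a 1.2-fold lower number from compound 3 to compound 4 (0.06 log units; within the scatter). Compound 4 is therefore estimated at 62000 nM in this assay, within a range from 28000 nM to 140000 nM.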

Compound 4, half-maximal inhibitory concentration: 73000 nM
Beside the measured number, compound 4's estimate is 1.2-fold (0.07 log units) below it; measured number inside the range.
By their numbers in this assay, from the lowest: compounds 1, 2, 3 and 4 (each within the scatter of the next).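

Compound 4 keeps the atoms of compound 3 but joins them differently, as 2-(methoxymethyl)-1-methylpropyl, and in this assay this rearrangement leaves the number in place (a 1.0-fold higher number from compound 3 to compound 4 (0.01 log units; within the scatter)). The earlier compounds shown here showed this insensitivity only for a change of configuration and for a swap of the branched group; it now also covers a change in how the branched group is connected, and the same holds against the other two compounds (a 1.3-fold higher number from compound 2 to compound 4 (0.12 log units; within the scatter); a 1.4-fold higher number from compound 1 to compound 4 (0.13 log units; within the scatter)). Nothing on hand accounts for this flat response.

The compounds shown leave open whether an amine, a carboxylic acid or a longer chain on this saturated chain carbon would move the number beyond the scatter. They also cannot tell how much the two aromatic rings, the same throughout, contribute to the cytotoxicity.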